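The compounds below may be only part of what the source reports. "The series", "measured", "known", "first", "only" and "open" are said of these compounds alone.

Compound 1, `Cc1nc2ccccc2c(=O)n1NC(=O)Nc1ccc(Cl)cc1`, gives 48% in a functional assay on the whole organism for inhibition, with Mus musculus as the target, with a stated time of 1 h, at a dose of 100 mg/kg by the intraperitoneal route; a higher number here means more inhibition at the dose given (going by the name of the read-out), a lower number less inhibition.
Compound 2, `Cc1ccccc1NC(=O)Nn1c(C)nc2ccccc2c1=O`, gives 51% in this assay.

Among the measured compounds shown here, compound 2 is one of only two compounds measured so far, and its sole neighbour is compound 1. The step between them, a number 3 percentage points higher from compound 1 to compound 2 (within the scatter), lies within the scatter, so the two readings cannot be told apart on the numbers shown.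

Compound 3, `Cc1nc2ccccc2c(=O)n1NC(=O)Nc1ccc(Br)cc1`, has not yet been tested. It differs from compound 2 in a single place: 4-bromophenyl in place of 2-methylphenyl on an amide-type nitrogen. For the measured compounds named here, one measured step bears on this spot, the one that exchanged the group on the amide-type nitrogen, and it was a number 3 percentage points higher from compound 1 to compound 2 (within the scatter), a change within the scatter. Compound 1 already carried a 4-chlorophenyl on that nitrogen, a group closely resembling the 4-bromophenyl of compound 3. In this assay compound 1 read 48%. No shift beyond the scatter is therefore expected; the estimated step from compound 2 to compound 3 is a number 3 percentage points lower from compound 2 to compound 3 (within the scatter). Compound 3 is expected to give about 48%, with a range from 35% to 60%.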

Compound 3, a percentage reported as inhibition, in the whole organism at one dose (the size of the read-out at that dose, not a potency): 51%
Beside the measured number, compound 3's estimate is 3 percentage points below it; measured number inside the range.
By their numbers in this assay, from the lowest: compounds 1, 2 and 3 (each within the scatter of the next).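

In this assay, placing 4-bromophenyl where 2-methylphenyl stood on the amide-type nitrogen gives no change at the digits printed from compound 2 to compound 3 (within the scatter), while bromo in place of chloro on an aromatic carbon gives a number 3 percentage points higher from compound 1 to compound 3 (within the scatter). Until now this position rested on a single exchange, but it now holds three substituted phenyl groups that cannot be told apart by this single-dose read-out, and the second step shows that changing only the halogen on the ring also leaves the reading within the scatter. Nothing offered here explains why the three readings lie so close together.

From the compounds shown here alone, what stays open is whether this insensitivity extends beyond substituted phenyl rings, since every group seen so far on that nitrogen is one, and a longer alkyl chain or a phenyl ring carrying an amine or a carboxylic acid could read quite differently. A reading at one dose is also not a potency, so compounds that cannot be separated here might still differ at other doses.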